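Notes on sulfonyl substitution within the shared core

The source may hold more compounds than are shown below. What is called first, only, known or untested is meant among the compounds shown, and "the series" means these compounds.

Three compounds of the shared core have been run in an ADME assay on CHO cells (Cricetulus griseus) for cytotoxicity, read by MTT assay; on this read-out lower numbers stand for stronger inhibition and higher numbers for weaker inhibition. Compound 1 `O=S(=O)(NCCO)c1cccc(Nc2ccc3nccc(-c4ccncc4)c3n2)c1` gives 4000 nM in this assay. Compound 2 `NS(=O)(=O)c1cccc(-c2ccc3nccc(-c4ccncc4)c3n2)c1` gives 2000 nM in this assay, the lowest of the two numbers, with compound 1 as the nearest and within the scatter. Compound 3 `O=S(=O)(NCc1ccccc1)c1cccc(Nc2ccc3nccc(-c4ccncc4)c3n2)c1` reaches only a limit of the assay, > 50000 nM, which is the limit of > 50000 nM in this assay, at which 1 of the 3 values shown sits. For the measured compounds named here, the one measured step is an at least 12-fold higher number from compound 1 to compound 3 (1.09 log units; beyond the scatter), a change on the carbon bound to the sulfonamide nitrogen.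

Compound 4 `C[C@@H]1CN(S(=O)(=O)c2cccc(-c3ccc4nccc(-c5ccncc5)c4n3)c2)C[C@H](C)N1` differs from compound 2 by 3,5-dimethylpiperazin-1-yl in place of amino on a sulfonyl sulfur. Going by the values given here, no step on the sulfonyl sulfur itself has been measured, so the step from compound 1 to compound 3 is the only guide, and it concerns a different place. Because an at least 12-fold higher number from compound 1 to compound 3 (1.09 log units; beyond the scatter) went toward weaker inhibition when a larger group entered, compound 4 is expected to move the same way, by a 3.0-fold higher number from compound 2 to compound 4 (0.48 log units; beyond the scatter). Compound 4 is estimated at 6000 nM, within 2000 nM to 25000 nM.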

Compound 4, half-maximal inhibitory concentration: 6000 nM
Beside the measured number, compound 4's estimate shows no gap at the digits printed, and the stated range covers the measured number.
By their numbers in this assay, from the lowest: compounds 2, 1 and 4 (each within the scatter of the next, the first and the last beyond it). At a limit, above all of these: compound 3.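

The sulfonyl sulfur of the shared core now has a measured step of its own: in this assay the change to 3,5-dimethylpiperazin-1-yl in place of amino gives a 3.0-fold higher number from compound 2 to compound 4 (0.48 log units; beyond the scatter), toward weaker inhibition. For the compounds shown here, the step is modest, and it is the first reading at a sulfonyl sulfur whose other neighbour is an aromatic carbon, so the change in number here can be read apart from the change on the carbon bound to the sulfonamide nitrogen. Nothing measured here bears on why the number moves, and the step cannot be divided among the ring, the two methyl groups and the 2 defined stereocentres.

From the compounds shown here alone, a plain piperazine or a morpholine on the sulfonyl sulfur would separate the ring from the methyl groups, and that remains open. Also open, going by these compounds, is whether the same change would give a similar step on the core of compound 1.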